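A few compounds are considered here, and "the series" means these few. Any claim that something is new, unique, unknown or untested is made for them only; others in the source may bear on it.

Of the compounds shown here, three have numbers so far in an ADME assay on Caco-2 cells (Homo sapiens) for permeability, read by LC-MS, in the apical to basolateral direction, with a stated time of 60 min, at pH 6.5 (on this read-out lower numbers stand for lower permeability and higher numbers for higher permeability), from which to read the next step. Compound 1 (`O=C(NCc1cc(Cl)ccc1-n1cnnn1)[C@@H]1C[C@@H]2C[C@@H]2N1C(=O)[C@H](O)CC1CC1`) gives 3.6 10^-6 cm/s and stands second highest of the three. Compound 2 (`CC(C)(C)[C@@H](O)C(=O)N1N=CC[C@H]1C(=O)NCc1cc(Cl)ccc1-n1cnnn1`) reads higher at 15 10^-6 cm/s and compound 3 (`O=C(NCc1cc(Cl)ccc1-n1cnnn1)[C@@H]1[C@H]2C[C@H]2CN1C(=O)[C@H](O)Cn1cccn1`) reads lower at 0.31 10^-6 cm/s and both gaps lie beyond the usual scatter.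

Compound 4 (`CC(C)(C)[C@@H](O)C(=O)N1[C@H](C(=O)NCc2cc(Cl)ccc2-n2cnnn2)C[C@@H]2C[C@@H]21`) keeps the core of compound 1 and changes one group (tert-butyl in place of cyclopropylmethyl on a saturated chain carbon bound to a carbonyl carbon and an oxygen on a saturated carbon): tert-butyl in place of cyclopropylmethyl on a saturated chain carbon bound to a carbonyl carbon and an oxygen on a saturated carbon. Within the data shown here, no measured pair isolates this change. Among the measured compounds shown here, compound 2 at 15 10^-6 cm/s is the only measured compound carrying tert-butyl, but its core differs from that of compound 1, so it offers only a loose hint of direction. In this assay a small rise is expected, and the estimated step (a 1.7-fold higher number from compound 1 to compound 4 (0.22 log units; within the scatter)) stays within the usual scatter. For compound 4 the expected value is 6 10^-6 cm/s with an estimated range (2.5 10^-6 cm/s to 14 10^-6 cm/s).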

Compound 4, apparent permeability: 16 10^-6 cm/s
For compound 4 the middle estimate is 2.7-fold (0.43 log units) below the measured one; the whole stated range lies below it.
By their numbers in this assay, from the lowest: compound 3; then compound 1; then compounds 2 and 4 (each within the scatter of the next).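

In this assay, among these compounds, tert-butyl in place of cyclopropylmethyl on a saturated chain carbon bound to a carbonyl carbon and an oxygen on a saturated carbon gives a 4.4-fold higher number from compound 1 to compound 4 (0.65 log units; beyond the scatter), the first step here that isolates a change at this position on one core. The two groups have the same count of heavy atoms and neither has hydrogen-bond donors or acceptors; in these counts, the difference is that the three-membered ring of cyclopropylmethyl leaves and tert-butyl has no ring. Nothing measured here accounts for the size of the step.

The compounds shown leave open whether the same exchange gives a similar step on other cores. They also leave open how this read-out responds at this position to a cyclobutyl group, a longer chain or an amine.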